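The source may report more compounds than this note shows. Statements on the series, on what has been measured and on what is new or still open speak of the compounds shown alone.

Measured compounds:
- compound 1 `CC#CC(CC(=O)O)c1ccc(OCc2ccc3nc(-c4ccc(F)cc4)cn3c2)cc1`: 623 nM
- compound 2 `CC#CC(CC(=O)O)c1ccc(OCc2ccc3nc(-c4ccccc4F)cn3c2)cc1`: 583 nM
- compound 3 `CC#CC(CC(=O)O)c1ccc(OCc2ccn3cc(-c4ccc(F)cc4)nc3c2)cc1`: 783 nM

All three were run in an assay on isolated protein for agonist activity at Free fatty acid receptor 1 (Homo sapiens); on this read-out higher numbers stand for an effect only at larger amounts of compound and lower numbers for an effect already at smaller amounts. Compound 1 gives 623 nM and compound 2 gives 583 nM; the two values lie within the scatter of each other, so nothing is said about their order. The change from compound 1 to compound 2 is 2-fluorophenyl in place of 4-fluorophenyl on an aromatic carbon, and it made a 1.1-fold lower number from compound 1 to compound 2 (0.03 log units; within the scatter). Compound 3 carries a different core; the difference between the core of compound 1 and the core of compound 3 is not broken down here. Compound 3 gives 783 nM, within the scatter of both compound 1 and compound 2.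

Compound 4 `CC#CC(CC(=O)O)c1ccc(OCc2ccn3cc(-c4ccccc4F)nc3c2)cc1` has not yet been measured in this assay. It differs from compound 3 by 2-fluorophenyl in place of 4-fluorophenyl on an aromatic carbon, the same change that was made from compound 1 to compound 2, at a place described in the same words. Because that earlier change gave a 1.1-fold lower number from compound 1 to compound 2 (0.03 log units; within the scatter), the step from compound 3 to compound 4 is expected to be small, estimated at a 1.1-fold lower number from compound 3 to compound 4 (0.02 log units; within the scatter). Compound 4 is therefore expected to give about 740 nM in this assay, with a likely range from 350 nM to 1600 nM. This rests on one prior pair only, so the expectation carries the uncertainty of a single example.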

Compound 4, half-maximal effective concentration: 705 nM
Beside the measured number, compound 4's estimate is 1.0-fold (0.02 log units) above it, within the range that was stated.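

In this assay, 2-fluorophenyl in place of 4-fluorophenyl on the core of compound 3 gave a 1.1-fold lower number from compound 3 to compound 4 (0.05 log units; within the scatter). On the two cores shown, this change reads the same, and the steps give no sign that the core alters its effect: the same change on two cores in this assay, a 1.1-fold lower number (0.03 log units; within the scatter) from compound 1 to compound 2 and a 1.1-fold lower number (0.05 log units; within the scatter) from compound 3 to compound 4, 1.0-fold (0.02 log units) apart, within the scatter of two such steps. Within the data shown here, this shows only that the swap between these two fluorophenyl groups stays within the scatter on both cores; it gives no order between the members of either pair, and it does not show that a step large enough to read would carry from one core to the other, or that the same agreement would hold on a third core.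

The compounds shown leave open how far this place tolerates anything other than a fluorophenyl group, as a plain phenyl, a chlorophenyl or a methoxyphenyl would each test a real change on both cores rather than a shift of the same fluorine. They also leave open whether any such step would stay alike across the two cores, and how an amide or a tetrazole in place of the carboxylic acid would read in this assay.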